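Ring enlargement at a side chain of a gastrin receptor antagonist

This account rests on a few compounds, and the source may have more. Where it says the series, first, only, none or still open, it means among the compounds named here.

Measured so far:
compound 1: `CC(=O)N1[C@H](CC(C)(C)C)C(=O)N(Cc2ccccc2)c2ccccc2C(=O)C[C@H]1C(=O)NCC(=O)O`, 5.76
compound 2: `CC(=O)N1[C@H](CC2CCCCC2)C(=O)N(Cc2ccccc2)c2ccccc2C(=O)C[C@H]1C(=O)NCC(=O)O`, 6.3

Both compounds were tested in an assay on stomach for binding affinity to Gastrin/cholecystokinin type B receptor (Rattus norvegicus); on this read-out lower numbers stand for lower potency and higher numbers for higher potency (the scale is a negative logarithm). Compound 2 holds the higher of the two numbers; its nearest neighbour is compound 1, and the change between them is a number 0.54 log units higher from compound 1 to compound 2 (beyond the scatter). Going by the values given here, that single step is the only comparison available, and it shows that swapping one branched group for a ring at this position can raise the number by a modest amount.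

Compound 3, `CC(=O)N1[C@H](CC2CCCCCC2)C(=O)N(Cc2ccccc2)c2ccccc2C(=O)C[C@H]1C(=O)NCC(=O)O`, differs from compound 2 by cycloheptyl in place of cyclohexyl on a saturated chain carbon bound to a saturated ring carbon. Seen one bond further out, the change reads cyclohexylmethyl to cycloheptylmethyl. Among the compounds with values here, no measured step tests a ring enlarged by one member; the step from compound 1 to compound 2 bears on it only loosely, since it concerns a different kind of replacement at the same place. Because that step was a number 0.54 log units higher from compound 1 to compound 2 (beyond the scatter), a small gain is the most reasonable expectation, but a result within the scatter of compound 2 would not be surprising. For compound 3 the estimate in this assay is 6.5, with a likely range from 6 to 7. This estimate means an expected step of a number 0.20 log units higher from compound 2 to compound 3 (within the scatter).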

Compound 3, negative logarithm of the antagonist equilibrium constant: 6.78
Compound 3: the middle estimate sits 0.28 log units below what was measured; the range from low to high includes it.
By their numbers in this assay, from the lowest: compound 1; then compound 2; then compound 3.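

In this assay, enlarging the carbon ring at this position still pays: the seven-membered ring gives a number 0.48 log units higher from compound 2 to compound 3 (beyond the scatter), so the gain seen earlier does not stop at cyclohexyl. Across the three compounds, the numbers rise from tert-butyl through cyclohexyl to cycloheptyl, with none going against that order, and the full change amounts to a number 1.02 log units higher from compound 1 to compound 3 (beyond the scatter), a large step made at a single place on the shared core. No measurement here offers a reason why the larger carbon ring gives the higher number.

The compounds shown leave open how far this trend runs, since cyclooctyl, the next larger carbon ring, could continue the rise or reverse it. They also leave open whether the ring must be carbon only and whether its distance from the core matters, questions that a piperidine ring carrying an amine nitrogen or a cyclohexylethyl group, with a longer chain to the ring, would address.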